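Removing a chloro group from compound 1: solubility expectations

The source may hold more compounds than are shown below. What is called first, only, known or untested is meant among the compounds shown, and "the series" means these compounds.

Measured compounds:
- compound 1 `O=C(CCc1ccc2[nH]c(-c3ccc(Cl)s3)nc2c1)Nc1ccc(N2CCOCC2=O)c(Cl)c1`: < 10 ug/mL
- compound 2 `CC1CC(c2ccc3[nH]c(-c4ccc(Br)s4)nc3c2)=NNC1=O`: < 10 ug/mL

In a physicochemical assay for solubility, in phosphate buffer, at pH 7.0 (a lower number here means a less soluble compound, a higher number a more soluble compound), compound 1 gives < 10 ug/mL, which is a limit of the assay and not a number. Compound 2 likewise sits at a limit, and in this assay compound 2 gives < 10 ug/mL. Both values shown thus rest at the limit of < 10 ug/mL in this assay, at which 2 of the 2 values shown sit, so compound 1 cannot be placed above or below any other compound on the numbers available.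

Compound 3 `O=C(CCc1ccc2[nH]c(-c3ccc(Cl)s3)nc2c1)Nc1ccc(N2CCOCC2=O)cc1` has not yet been measured in this assay. It differs from compound 1 by hydrogen in place of chloro on an aromatic carbon, a hydrogen in place of chloro on an aromatic carbon. Among the compounds with values here, no measured pair shows this change, so no step size is known. The step from compound 1 to compound 3 is expected to be small, with a slight rise in solubility, as an at least 1.2-fold higher number from compound 1 to compound 3 (0.07 log units; that floor lies within the scatter). Compound 3 is estimated at 12 ug/mL, within 3 ug/mL to 40 ug/mL, and may again be reported only as a limit.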

Compound 3, solubility: < 10 ug/mL
Compound 3 was reported as a limit (the forecaster's own chance of this, stated with the estimate: 50%); at least 1.2-fold (0.07 log units) between middle value and limit.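

In this assay compound 3 gives < 10 ug/mL, which is a limit of the assay and not a number. No step can be read from compound 1 to compound 3 because both compounds rest at the same limit: the limit of < 10 ug/mL in this assay, at which 3 of the 3 values shown sit. The compounds shown leave open whether hydrogen in place of chloro on an aromatic carbon changes the read-out at all, and by how much.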